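The source may hold more compounds than are shown below. What is called first, only, known or untested is meant among the compounds shown, and "the series" means these compounds.

Compound 1 `C#CCn1c(=O)c(C=O)cc2cc(OC)ccc21` and compound 2 `C#CCn1c(=O)c(C=O)cc2cc(C)ccc21` share a core that carries an aldehyde, and in a functional assay on NCI-H460 cells (Homo sapiens) for cytotoxicity, read by MTT assay, with a stated time of 24 h (a lower number here means a stronger inhibitor, a higher number a weaker inhibitor), compound 1 gives only the assay limit of > 100000 nM. In this assay compound 2 likewise gives only the limit of > 100000 nM. The change between them, (methyl in place of methoxy on an aromatic carbon), therefore makes a step that the two limits leave unreadable from compound 1 to compound 2, because the limit of > 100000 nM in this assay, at which 2 of the 3 values shown sit, hides its size. Compound 3 `C#CCn1c(=O)c(/C=C/C(=O)/C=C(O)/C=C/c2ccc(O)c(OC)c2)cc2cc(OC)ccc21` carries a longer unsaturated chain instead; the difference between its core and the core of compound 1 is not broken down here. In this assay compound 3 gives 38100 nM. Compound 4 `C#CCn1c(=O)c(/C=C/C(=O)/C=C(O)/C=C/c2ccc(O)c(OC)c2)cc2cc(C)ccc21` repeats the same change, (methyl in place of methoxy on an aromatic carbon), on the core of compound 3. Since the measured step from compound 1 to compound 2 is unreadable, compound 4 is expected to stay close to compound 3, a step of a 1.2-fold higher number from compound 3 to compound 4 (0.07 log units; within the scatter). Compound 4 is estimated at 45000 nM, between 18000 nM and 110000 nM.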

Compound 4, half-maximal inhibitory concentration: 21800 nM
For compound 4 the middle estimate is 2.1-fold (0.31 log units) above the measured one, and the stated range covers the measured number.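

In this assay, methyl in place of methoxy on an aromatic carbon makes a 1.7-fold lower number from compound 3 to compound 4 (0.24 log units; within the scatter), so on this core the change cannot be told apart from the scatter of repeated measurements. Among these compounds, whether the change carries from one core to the other cannot be judged, because the step from compound 1 to compound 2 has no readable size: the limit of > 100000 nM in this assay, at which 2 of the 4 values shown sit. The single readable pair therefore describes one core only and sets no rule for the series.

The compounds shown leave open how an amine or a chlorine on the same aromatic carbon would read in this assay. Also open, on these data alone, is how a carboxylic acid in place of the aldehyde would read on the shared core.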